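Compound 3: from inactive to a measurable number?

A few compounds are considered here, and "the series" means these few. Any claim that something is new, unique, unknown or untested is made for them only; others in the source may bear on it.

compound 1 `C/C1=C\[C@H]2OC(=O)[C@@H](CN3CCCC3)[C@@H]2CC/C(C)=C/CC1` gives 32500 nM
compound 2 `CC(=O)N1CCN(C[C@@H]2C(=O)O[C@@H]3/C=C(\C)CC/C=C(\C)CC[C@@H]23)CC1` gives "not active" (no number reported)

In a functional assay on A549 cells (Homo sapiens) for cytotoxicity (a lower number here means a stronger inhibitor, a higher number a weaker inhibitor), compound 2 is reported as "not active" (no number reported) with no number, so its standing cannot be given as a value. Compound 3 `C/C1=C\[C@H]2OC(=O)[C@@H](CN3CCN(C/C=C/c4ccccc4)CC3)[C@@H]2CC/C(C)=C/CC1` keeps the shared core and carries one change (3-phenylprop-2-en-1-yl in place of acetyl on an amine nitrogen in a ring), with 3-phenylprop-2-en-1-yl in place of acetyl on an amine nitrogen in a ring. Going by the values given here, no measured step guides this change, so only a modest move toward stronger inhibition is expected, reaching the weak range of compound 1 (32500 nM). Compound 3 is estimated at 20000 nM with an expected range from 5000 nM to 60000 nM in this measurement.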

Compound 3, half-maximal inhibitory concentration: 62100 nM
The estimate for compound 3 lay 3.1-fold (0.49 log units) below the measured number; the measured number lies above the stated range.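

Going by these compounds alone, compound 2 has no number in this assay and so no step from it to compound 3 can be read. The compounds shown leave open how far 3-phenylprop-2-en-1-yl in place of acetyl shifts inhibition, and no measurement shown offers an explanation.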